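The source may hold more compounds than are shown below. What is called first, only, known or untested is meant among the compounds shown, and "the series" means these compounds.

Measured compounds:
- compound 1 `Cc1nc2c3ccccc3ccc2c2nc3c(ccc4ccccc43)c(-c3cccnc3)c12` gives 3960 nM in a functional assay on AGS cells (Homo sapiens) for cytotoxicity, read by MTT assay, with a stated time of 48 h; on this read-out higher numbers stand for weaker inhibition and lower numbers for stronger inhibition
- compound 2 `Cc1nc2c3ccccc3ccc2c2nc3c(ccc4ccccc43)c(-c3cccc4ccccc34)c12` gives 12100 nM in this assay

Compound 1 holds the lowest of the two numbers in this assay; its nearest neighbour is compound 2, reached by a 3.1-fold higher number from compound 1 to compound 2 (0.49 log units; beyond the scatter) when naphthalen-1-yl takes the place of pyridin-3-yl on an aromatic carbon. Compound 3 `Cc1nc2c3ccccc3ccc2c2nc3c(ccc4ccccc43)c(-c3cc(O)nc4ccccc34)c12` has not yet been measured. It departs from compound 1 by 2-hydroxyquinolin-4-yl in place of pyridin-3-yl on an aromatic carbon.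

Within the data shown here, the one measured step that bears on this change is a 3.1-fold higher number from compound 1 to compound 2 (0.49 log units; beyond the scatter): there, too, a single six-membered ring gave way to a fused two-ring group at the same aromatic carbon, and the number rose beyond the scatter. Among the measured compounds shown here, the group entering in compound 3 is again a fused two-ring group, now carrying a hydroxyl and a ring nitrogen, for which no step among the measured compounds gives guidance. On this basis a modest rise in the number, of about the size seen from compound 1 to compound 2, is expected for compound 3, which would correspond to a 2.0-fold higher number from compound 1 to compound 3 (0.31 log units; beyond the scatter). Compound 3 is therefore estimated at 8000 nM, within a range from 3000 nM to 20000 nM.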

Compound 3, half-maximal inhibitory concentration: 15800 nM
Estimate against measurement, compound 3: 2.0-fold (0.30 log units) below; measured number inside the range.
By their numbers in this assay, from the lowest: compound 1; then compounds 2 and 3 (each within the scatter of the next).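

In this assay, a second fused two-ring group at this aromatic carbon, opposite the ring nitrogen, again lies beyond the scatter of compound 1, with a 4.0-fold higher number from compound 1 to compound 3 (0.60 log units; beyond the scatter). Set against the naphthalen-1-yl group, the 2-hydroxyquinolin-4-yl group gives a 1.3-fold higher number from compound 2 to compound 3 (0.12 log units; within the scatter), so this read-out does not separate the fused group carrying a hydroxyl and a ring nitrogen from the fused group of carbon only. Both fused groups thus stand apart from pyridin-3-yl in the same direction, a pattern that rests on these three compounds alone, and no measurement at hand accounts for it.

From the compounds shown here alone, it remains open whether a single six-membered ring of carbon only, such as phenyl, would stay with compound 1 or join compounds 2 and 3, which would help to separate the part played by the ring nitrogen of pyridin-3-yl from that of the second fused ring. Also open, going by these compounds, is whether an amine or a carboxylic acid placed on the pyridin-3-yl ring would move the number at all in either direction.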